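The source may hold more compounds than are shown below. What is called first, only, known or untested is meant among the compounds shown, and "the series" means these compounds.

Compound 3 `CCCCc1ccc(CNC(=O)N(C)C)c(=O)n1Cc1ccc(-c2ccccc2-c2nn[nH]n2)cc1` gives 2 nM in a functional assay (aorta) for antagonist activity, with Oryctolagus cuniculus as the target (on this read-out higher numbers stand for weaker inhibition and lower numbers for stronger inhibition), the second highest of the three numbers recorded. Compound 1 `CCCCc1ccc(C)c(=O)n1Cc1ccc(-c2ccccc2-c2nn[nH]n2)cc1` gives 7 nM, and compound 2 `CCCCc1ccc(CN(C)S(C)(=O)=O)c(=O)n1Cc1ccc(-c2ccccc2-c2nn[nH]n2)cc1` gives 0.2 nM. Compound 4 `CCCCc1ccc(CNS(C)(=O)=O)c(=O)n1Cc1ccc(-c2ccccc2-c2nn[nH]n2)cc1` differs from compound 3 by methylsulfonyl in place of dimethylcarbamoyl on an amine nitrogen. The step that bears most directly on this is a 10-fold higher number from compound 2 to compound 3 (1.00 log units; beyond the scatter), since compound 2 carries the same methylsulfonyl group on that nitrogen; the steps of a 35-fold lower number from compound 1 to compound 2 (1.54 log units; beyond the scatter) and a 3.5-fold lower number from compound 1 to compound 3 (0.54 log units; beyond the scatter) point the same way. Compound 4 is therefore expected to show a lower number than compound 3 in this assay, a step of a 4.0-fold lower number from compound 3 to compound 4 (0.60 log units; beyond the scatter), because of a 10-fold higher number from compound 2 to compound 3 (1.00 log units; beyond the scatter). The estimate for compound 4 is 0.5 nM, within a range of 0.15 nM to 1.5 nM.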

Compound 4, half-maximal inhibitory concentration: 2 nM
Compound 4: middle estimate off by 4.0-fold (0.60 log units), on the low side, and the stated range ends below it.
By their numbers in this assay, from the lowest: compound 2; then compounds 3 and 4 (each within the scatter of the next); then compound 1.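

In this assay, methylsulfonyl in place of dimethylcarbamoyl on the amine nitrogen gives no change at the digits printed from compound 3 to compound 4 (within the scatter), so the two groups cannot be told apart at this position when that nitrogen carries hydrogen. Hydrogen in place of methyl on the sulfonamide nitrogen gives a 10-fold higher number from compound 2 to compound 4 (1.00 log units; beyond the scatter), which ties the low number of compound 2 to that methyl, while the methanesulfonamido group still gives a 3.5-fold lower number from compound 1 to compound 4 (0.54 log units; beyond the scatter) and so keeps part of the difference from the parent. Nothing available explains this dependence on the methyl. From the compounds shown here alone, whether ethyl on the sulfonamide nitrogen would match methyl remains open, as does whether an acetyl group on the amine nitrogen would match methylsulfonyl and dimethylcarbamoyl.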